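A few compounds are considered here, and "the series" means these few. Any claim that something is new, unique, unknown or untested is made for them only; others in the source may bear on it.

Of the compounds shown here, three have been measured in a functional assay on MRC5 cells (Homo sapiens) for inhibition, read by microscopy and resazurin assay, with a stated time of 72 h; on this read-out higher numbers stand for weaker inhibition and lower numbers for stronger inhibition. Compound 1, `COC(=O)[C@H](CC(C)C)NC(=O)c1cccc(/C=C2\SC(=O)N(CC(=O)NOCc3ccccc3)C2=O)c1`, carries an isobutyl group on a saturated chain carbon bound to an amide-type nitrogen and a carbonyl carbon. In this assay compound 1 gives only a limit, > 128000 nM. Compound 2, `COC(=O)[C@@H](NC(=O)c1cccc(/C=C2\SC(=O)N(CC(=O)NOCc3ccccc3)C2=O)c1)C(C)C`, has isopropyl in place of that isobutyl. In this assay compound 2 also gives only a limit, > 128000 nM. The step that the two limits leave unreadable from compound 1 to compound 2 therefore cannot be read, since both ends are limits rather than numbers. Compound 3, `C=CCONC(=O)Cn1cc(C(=O)NCC(=O)N[C@@H](CC(C)C)C(=O)O)c2ccccc21`, is built on a different core. In this assay compound 3 likewise gives only a limit, > 128000 nM. Among the compounds with values here, all three values thus sit at the same ceiling, (the limit of > 128000 nM in this assay, at which 3 of the 3 values shown sit), and no measured step shows any change beyond the scatter.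

Compound 4, `C=CCONC(=O)Cn1cc(C(=O)N[C@@H](C)C(=O)N[C@@H](CC(C)C)C(=O)O)c2ccccc21`, differs from compound 3 by methyl in place of hydrogen on a saturated chain carbon bound to an amide-type nitrogen and a carbonyl carbon. Within the data shown here, the only step of similar kind, from compound 1 to compound 2, is unreadable, so it offers no size to carry over; the shared ceiling at the limit of > 128000 nM in this assay, at which 3 of the 3 values shown sit, is the sole guide. The expected step of a number no higher from compound 3 to compound 4 (the limit leaves the size open) is therefore none beyond the scatter. Compound 4 is estimated to give 128000 nM, with a range from 40000 nM to 400000 nM, and most likely again only a limit.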

Compound 4, half-maximal inhibitory concentration: > 128000 nM
Compound 4: a limit, no number; the forecaster's own chance of this, stated with the estimate: 85%; the middle value lies on the limit itself.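

In this assay compound 4 gives > 128000 nM as a limit and not a number, so the step from compound 3 to compound 4 cannot be read. The compounds shown leave open how strongly any of them acts on these cells, and what changes that, because all their values share one ceiling: the limit of > 128000 nM in this assay, at which 4 of the 4 values shown sit.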